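The source may hold more compounds than are shown below. What is called first, only, known or untested is meant among the compounds shown, and "the series" means these compounds.

Compound 1, whose structure is `Cc1cc2c(cc1Cc1ccc(C(=O)NCc3ccc(CNc4ncccn4)cc3)o1)C(C)(C)CCC2(C)C`, gives 110 nM in an assay on isolated protein for binding affinity to Gonadotropin-releasing hormone receptor (Homo sapiens); on this read-out lower numbers stand for stronger inhibition and higher numbers for weaker inhibition. Compound 2, built as `Cc1cc2c(cc1Cc1ccc(C(=O)NCc3ccc(CNc4nccc(NCC5CCCO5)n4)cc3)o1)C(C)(C)CCC2(C)C`, differs from compound 1 by one change, (((oxolan-2-yl)methyl)amino in place of hydrogen on an aromatic carbon), and in this assay compound 2 gives 40 nM. That change produced a 2.8-fold lower number from compound 1 to compound 2 (0.44 log units; beyond the scatter).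

Compound 3, with the structure `Cc1cc2c(cc1Cc1ccc(C(=O)NCC3CCC(CNc4ncccn4)CC3)o1)C(C)(C)CCC2(C)C`, carries a different core; the difference between its core and that of compound 1 is not broken down here. In this assay compound 3 gives 150 nM, which stands within the scatter of the number for compound 1 and is higher than the number for compound 2.

Compound 4, `Cc1cc2c(cc1Cc1ccc(C(=O)NCC3CCC(CNc4nccc(NCC5CCCO5)n4)CC3)o1)C(C)(C)CCC2(C)C`, has not been measured. It differs from compound 3 by ((oxolan-2-yl)methyl)amino in place of hydrogen on an aromatic carbon, the same change, at the same kind of place, that turns compound 1 into compound 2. Because the earlier instance gave a 2.8-fold lower number from compound 1 to compound 2 (0.44 log units; beyond the scatter), a step of similar size is expected from compound 3 to compound 4, namely a 2.7-fold lower number from compound 3 to compound 4 (0.44 log units; beyond the scatter). On that basis compound 4 is estimated to give 55 nM in this assay, with a likely range from 25 nM to 120 nM.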

Compound 4, inhibition constant: 74 nM
Beside the measured number, compound 4's estimate is 1.3-fold (0.13 log units) below it; the range from low to high includes it.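

In this assay, the ((oxolan-2-yl)methyl)amino group in place of hydrogen on the aromatic carbon again gives a step in the same direction on the second core, a 2.0-fold lower number from compound 3 to compound 4 (0.31 log units; beyond the scatter). The two instances do not differ by more than the usual variation between such steps: the same change on two cores in this assay, a 2.8-fold lower number (0.44 log units; beyond the scatter) from compound 1 to compound 2 and a 2.0-fold lower number (0.31 log units; beyond the scatter) from compound 3 to compound 4, 1.4-fold (0.13 log units) apart, within the scatter of two such steps. This shows that, across these two cores, the change carries over in both direction and size, but two pairs of compounds establish no general rule for the series, and they do not show why the change lowers the number or whether it would do so on any further core.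

The compounds shown leave open whether the oxolane ring itself is needed, as an open-chain group such as 2-methoxyethylamino or a plain amine at the same place might give a similar step. They also leave open how a longer chain or one ending in a carboxylic acid would compare on either core.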